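Shifting a Chlorine Substituent: Expected Effect on Cytotoxicity

This account rests on a few compounds, and the source may have more. Where it says the series, first, only, none or still open, it means among the compounds named here.

Measured compounds in a functional assay on HCT-15 cells (Homo sapiens) for cytotoxicity, read by CCK-8 assay and cell counting, with a stated time of 2 days; on this read-out lower numbers stand for stronger inhibition and higher numbers for weaker inhibition:
compound 1 `Oc1ccc(-c2cc(-c3ccccc3)nc(-c3ccccc3Cl)c2)cc1` gives 4990 nM
compound 2 `Oc1ccc(-c2cc(-c3cccs3)nc(-c3ccccc3Cl)c2)cc1` gives 5430 nM
compound 3 `Oc1ccc(-c2cc(-c3ccco3)nc(-c3ccccc3Cl)c2)cc1` gives 5460 nM

All three measured compounds share a core carrying a 4-hydroxyphenyl group and a 2-chlorophenyl group, and differ only in the third aryl group. Compound 2 stands second highest of the three numbers; its nearest neighbour is compound 3, and its furthest is compound 1, yet every one of these separations lies within the scatter: a 1.1-fold higher number from compound 1 to compound 2 (0.04 log units; within the scatter), a 1.1-fold higher number from compound 1 to compound 3 (0.04 log units; within the scatter) and a 1.0-fold higher number from compound 2 to compound 3 (0.00 log units; within the scatter). Swapping phenyl, thiophen-2-yl and furan-2-yl at that position therefore leaves the read-out unchanged in practice.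

Compound 4 `Oc1ccc(-c2cc(-c3ccc(Cl)cc3)nc(-c3cccs3)c2)cc1` keeps the thiophen-2-yl group of compound 2 and changes the chlorinated ring: 4-chlorophenyl in place of 2-chlorophenyl on an aromatic carbon. Going by the values given here, none of the measured steps touches the chlorophenyl group, so no step bears directly on this change. Among the compounds with values here, since the only steps known are all flat, the step from compound 2 to compound 4 is expected to be small, with no clear direction, as a 1.1-fold lower number from compound 2 to compound 4 (0.04 log units; within the scatter).

Compound 4 is therefore estimated at 5000 nM, within a range from 2000 nM to 13000 nM.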

Compound 4, half-maximal inhibitory concentration: 6470 nM
The estimate for compound 4 lay 1.3-fold (0.11 log units) below the measured number; measured number inside the range.
By their numbers in this assay, from the lowest: compounds 1, 2, 3 and 4 (each within the scatter of the next).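

Going by these compounds alone, compound 4 gives the first look at the chlorinated ring, since every earlier step touched only the third aryl group. In this assay, placing 4-chlorophenyl instead of 2-chlorophenyl on the aromatic carbon next to the ring nitrogen gives a 1.2-fold higher number from compound 2 to compound 4 (0.08 log units; within the scatter), so this read-out does not separate the two placements of the chlorine, at least with a thiophen-2-yl group on the shared core. Together with the earlier steps, this means that all four compounds sit close together, whichever of these aryl groups is present and wherever the chlorine sits among the two placements shown; no measurement offered here speaks to why the numbers stay so close.

The compounds shown leave open whether this insensitivity holds for the chlorine shift when phenyl or furan-2-yl takes the place of thiophen-2-yl, and whether a chlorine-free phenyl, or a ring bearing an amine or a carboxylic acid in place of the chlorine, would separate from them. From the compounds shown here alone, all four also carry the 4-hydroxyphenyl group, so what a methoxy group in place of that hydroxyl, or another group at that site, would do to the read-out remains unknown.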